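A few compounds are considered here, and "the series" means these few. Any claim that something is new, unique, unknown or untested is made for them only; others in the source may bear on it.

In a functional assay on A549 cells (Homo sapiens), read by MTT assay, with a stated time of 72 h (on this read-out lower numbers stand for stronger inhibition and higher numbers for weaker inhibition), two compounds give a number and one reaches a limit. Compound 1 `C#Cc1cn([C@@H]2O[C@H](CO)[C@@H](O)[C@H]2O)c2ncnc(OC)c12` gives 8160 nM in this assay. Compound 2 `COc1ncnc2c1c(-c1ccco1)cn2[C@@H]1O[C@H](CO)[C@@H](O)[C@H]1O` gives 30 nM and so stands lowest of the two numbers, with compound 1 as the nearest value. For the measured compounds named here, the only measured step is a 270-fold lower number from compound 1 to compound 2 (2.43 log units; beyond the scatter), furan-2-yl in place of ethynyl on an aromatic carbon. Compound 3 `O=c1[nH]cnc2c1c(-c1cccs1)cn2[C@@H]1O[C@H](CO)[C@@H](O)[C@H]1O` reaches only a limit of this assay, > 20000 nM. That limit is the limit of > 20000 nM in this assay, at which 1 of the 3 values shown sits.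

Compound 4 `COc1ncnc2c1c(-c1ccoc1)cn2[C@@H]1O[C@H](CO)[C@@H](O)[C@H]1O` is not yet measured. It differs from compound 2 by furan-3-yl in place of furan-2-yl on an aromatic carbon. Going by the values given here, no measured step compares two attachment points of the same ring, so none bears directly on this change. The step from compound 1 to compound 2 shows that the group on this aromatic carbon sets the number strongly, but it swaps one group for another rather than turning a group around. The same ring, with the same atoms, should keep most of what compound 2 gains, so only a modest step is expected, likely toward a somewhat higher number, and perhaps within the scatter. The expected step is a 2.7-fold higher number from compound 2 to compound 4 (0.43 log units; beyond the scatter). Compound 4 is therefore estimated at 80 nM, in the range 15 nM to 500 nM.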

Compound 4, half-maximal inhibitory concentration: 1160 nM
Compound 4: middle estimate off by 15-fold (1.16 log units), on the low side, and the stated range ends below it.
By their numbers in this assay, from the lowest: compound 2; then compound 4; then compound 1. At a limit, above all of these: compound 3.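

In this assay, moving only the attachment point of the furan ring gives a 39-fold higher number from compound 2 to compound 4 (1.59 log units; beyond the scatter) even though furan-2-yl and furan-3-yl have the same atoms and the same counts of hydrogen-bond donors and acceptors. At this aromatic carbon, then, the number depends not only on which ring is attached but also on which ring atom carries the bond, something the earlier swap of ethynyl for furan-2-yl could not separate. Furan-3-yl still gives a 7.0-fold lower number from compound 1 to compound 4 (0.85 log units; beyond the scatter) against a 270-fold lower number from compound 1 to compound 2 (2.43 log units; beyond the scatter) for furan-2-yl, so this isomer keeps only part of the gain seen with furan-2-yl.

The compounds shown leave open whether the same sensitivity to the attachment point holds for other rings on this carbon, such as a phenyl or pyridine ring. They also leave open how an amine or a longer chain such as propyl would fare at this position, on the same core. The evidence at hand offers nothing that accounts for the gap between the two furans.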